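The compounds below may be only part of what the source reports. "The series", "measured", "known", "first", "only" and "open" are said of these compounds alone.

Three related compounds have been tested in a functional assay on HepG2 cells (Homo sapiens) for cytotoxicity (on this read-out higher numbers stand for weaker inhibition and lower numbers for stronger inhibition), and a fourth awaits testing. Compound 1 `Cc1c(S(=O)(=O)N/C(=N\O)Nc2ccc(Cl)cc2)sc2ccc(Cl)cc12` gives 140 ug/mL in this assay. Compound 2 `O=[N+]([O-])c1ccc(Oc2c(Cl)cc(S(=O)(=O)N/C(=N\O)Nc3ccc(Cl)cc3)cc2Cl)cc1` gives 22 ug/mL, and compound 3 `O=[N+]([O-])c1ccc(Oc2c(Cl)cc(S(=O)(=O)N/C(=N\O)Nc3ccc(Cl)cc3)cc2Cl)c(Cl)c1` gives 49 ug/mL. Compound 1 thus shows the highest number of the three, with its steps to compound 3 and to compound 2 both beyond the scatter. How the core of compound 1 differs from that of compound 2 is not broken down here.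

Compound 2 and compound 3 differ in one place: chloro in place of hydrogen on an aromatic carbon. This change produced a 2.2-fold higher number from compound 2 to compound 3 (0.35 log units; beyond the scatter).

The unmeasured compound 4 `Cc1c(S(=O)(=O)N/C(=N\O)Nc2ccc(Cl)c(Cl)c2)sc2ccc(Cl)cc12` is built from compound 1 by the same kind of change: chloro in place of hydrogen on an aromatic carbon. The surroundings are not the same, though: in the step from compound 2 to compound 3 the new chloro sits ortho to a large group and meta to a nitro group, whereas in compound 4 it sits ortho to a chloro group and meta to a large group, on a different core. Going by the values given here, only one measured example of this kind of change exists, and it points toward a somewhat higher number. Resting on that single step and on the value of compound 1, 140 ug/mL, compound 4 is expected to show a step of a 1.8-fold higher number from compound 1 to compound 4 (0.25 log units; within the scatter). The estimate for compound 4 is 250 ug/mL, with a likely range from 120 ug/mL to 500 ug/mL, and with compound 1 already standing high, the assay may report only a limit.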

Compound 4, half-maximal inhibitory concentration: > 300 ug/mL
Compound 4 ended at the assay's limit (the forecaster's own chance of this, stated with the estimate: 25%); middle value at least 1.2-fold (0.07 log units) from the limit.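

In this assay compound 4 gives > 300 ug/mL, which is a limit of the assay and not an exact number. Placing chloro on an aromatic carbon of the core of compound 1, which turns the 4-chlorophenyl into a 3,4-dichlorophenyl, gave an at least 2.1-fold higher number from compound 1 to compound 4 (0.33 log units; beyond the scatter), so weaker inhibition appears here as it did on the other core, and the two cores agree in direction: the same change on two cores in this assay, a 2.2-fold higher number (0.35 log units; beyond the scatter) from compound 2 to compound 3 and an at least 2.1-fold higher number (0.33 log units; beyond the scatter) from compound 1 to compound 4; the limit leaves it open whether they differ What this does not show is the true size of the step on the core of compound 1, so it cannot be said that the change carries over with the same size, and two pairs with the new chloro in different surroundings make no rule for other cores in the series.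

The compounds shown leave open whether another small group in the same place, such as fluoro, methyl or methoxy, would move the number in the same direction as chloro. They also leave open how an amine or a carboxylic acid at that place would read in this assay, and an exact value for compound 4 would be needed before the two chloro steps could be compared in size.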